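From chloro to methyl on the aromatic ring

The source may hold more compounds than are shown below. What is called first, only, known or untested is meant among the compounds shown, and "the series" means these compounds.

In a functional assay on A-375 cells (Homo sapiens) for antiproliferative activity, read by MTT assay, with a stated time of 72 h (a lower number here means a stronger inhibitor, a higher number a weaker inhibitor), compound 1 (`COc1cccc(N2C(=O)COc3ccc(-c4cnc5ccccc5c4)cc32)c1`) gives 23600 nM and compound 2 (`O=C1COc2ccc(-c3cccc(NS(=O)(=O)c4ccc(F)cc4)c3)cc2N1c1ccc(Cl)cc1`) gives 32500 nM on the two readings available. These two values lie within the scatter of each other, so compound 2 stands level with compound 1 on the numbers shown.

Compound 3 (`Cc1ccc(N2C(=O)COc3ccc(-c4cccc(NS(=O)(=O)c5ccc(F)cc5)c4)cc32)cc1`) has no reading yet. It differs from compound 2 in one place: methyl in place of chloro on an aromatic carbon with methyl in place of chloro on an aromatic carbon, para to a large group, so that 4-chlorophenyl becomes 4-methylphenyl.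

Among the compounds with values here, no measured pair differs in one place, so the data offer no direct guide to the size of this change. The expectation is therefore no step beyond the scatter, in either direction. The estimated change is a 1.1-fold lower number from compound 2 to compound 3 (0.03 log units; within the scatter) and is expected to stay within that scatter. Compound 2 at 32500 nM is the closest reference for this expectation. For compound 3 the expected value is 30000 nM with an estimated range from 14000 nM to 62000 nM in this assay once it is measured.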

Compound 3, half-maximal inhibitory concentration: 36200 nM
Compound 3: the middle estimate sits 1.2-fold (0.08 log units) below what was measured; the measured number falls inside the stated range.
By their numbers in this assay, from the lowest: compounds 1, 2 and 3 (each within the scatter of the next).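

Methyl in place of chloro on an aromatic carbon, para to a large group, gives a 1.1-fold higher number from compound 2 to compound 3 (0.05 log units; within the scatter) in this assay and is the first one-place comparison available in the series. With the rest of compound 2 held fixed, 4-chlorophenyl and 4-methylphenyl cannot be told apart in this read-out, so this single exchange gives no handle on the numbers at this position. No separate measurement bears on this result, and the step stands here as an observation alone.

Going by these compounds, whether the same position would keep its reading with a markedly different group, such as an amine, a carboxylic acid or a longer alkyl chain, stays open, since one exchange between two single-atom substituents samples very little of what could sit there. Also open, on these data alone, is whether methyl in place of chloro reads the same way on other parts of the series, as compound 1 differs from compound 2 in more than one place and offers no comparison for this exchange.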